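Adding Chlorine to an Aromatic Ring in Two Related Series

The source may hold more compounds than are shown below. What is called first, only, known or untested is meant among the compounds shown, and "the series" means these compounds.

In an assay on RBL-1 cells for inhibition of Polyunsaturated fatty acid 5-lipoxygenase (Rattus norvegicus) (on this read-out higher numbers stand for weaker inhibition and lower numbers for stronger inhibition), compound 1 `O=C1NCCN(c2ccccn2)N1` gives 26000 nM. Compound 2 `O=C1NCCN(c2cccc(Cl)n2)N1` carries chloro in place of hydrogen on an aromatic carbon and in this assay compound 2 gives 5600 nM, so a 4.6-fold lower number from compound 1 to compound 2 (0.67 log units; beyond the scatter). Compound 3 `CC1CN(c2ccccc2)NC(=O)N1O` rests on another core; the difference between the two cores is not broken down here. In this assay compound 3 gives 6000 nM, a number within the scatter of compound 2. Compound 4 `CC1CN(c2cccc(Cl)c2)NC(=O)N1O` differs from compound 3 by chloro in place of hydrogen on an aromatic carbon. Among the measured compounds shown here, this is the same kind of change as the one from compound 1 to compound 2, though not the same: there the chloro sits on a six-membered aromatic ring with 1 nitrogen, next to the ring nitrogen; here it sits on a six-membered aromatic ring of carbon only, meta to a group of 9 heavy atoms. For the measured compounds named here, the one earlier step, a 4.6-fold lower number from compound 1 to compound 2 (0.67 log units; beyond the scatter), is the only guide. For compound 4 a somewhat smaller step is expected, a 3.0-fold lower number from compound 3 to compound 4 (0.48 log units; beyond the scatter), and compound 4 is estimated at 2000 nM, with a likely range from 800 nM to 5000 nM.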

Compound 4, half-maximal inhibitory concentration: 3900 nM
The estimate for compound 4 lay 2.0-fold (0.29 log units) below the measured number, within the range that was stated.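

In this assay, chloro in place of hydrogen on an aromatic carbon gave a 1.5-fold lower number from compound 3 to compound 4 (0.19 log units; within the scatter), so on this core the effect of the change cannot be told apart from repeat scatter. Set beside the earlier step, the change did not carry over in size from one core to the other: the same change on two cores in this assay, a 4.6-fold lower number (0.67 log units; beyond the scatter) from compound 1 to compound 2 and a 1.5-fold lower number (0.19 log units; within the scatter) from compound 3 to compound 4, 3.0-fold (0.48 log units) apart, beyond the scatter of two such steps. Among the compounds shown here, this rests on only two pairs, which also differ in the ring that carries the chloro and in where it sits, so it shows that the step does not transfer unchanged, but not which difference between the pairs goes with the gap.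

The compounds shown leave open whether another group on the same carbon, such as methoxy or an amine, would give steps that differ between the two cores. They also leave open what chloro would do at other carbons of either ring.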